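Aminomethyl variation on the shared core: compound 4

A few compounds are considered here, and "the series" means these few. Any claim that something is new, unique, unknown or untested is made for them only; others in the source may bear on it.

Across the three measured compounds, the group on a saturated chain carbon bound to an aromatic carbon of the shared core is varied. In a functional assay for antagonist activity at transient receptor potential cation channel subfamily V member 1 (Homo sapiens) (on this read-out lower numbers stand for stronger inhibition and higher numbers for weaker inhibition), compound 1 `CCOCc1nc(Nc2ccc(C(F)(F)F)cc2)c2ccc(-c3ncccc3C(F)(F)F)cc2n1` gives 0.9 nM; compound 2 `CNCc1nc(Nc2ccc(C(F)(F)F)cc2)c2ccc(-c3ncccc3C(F)(F)F)cc2n1` gives 26 nM; compound 3 `FC(F)(F)c1ccc(Nc2nc(CNC3CCCCC3)nc3cc(-c4ncccc4C(F)(F)F)ccc23)cc1` gives 6 nM, the second highest number of the three. The steps leading to it are a 6.7-fold higher number from compound 1 to compound 3 (0.82 log units; beyond the scatter) and a 4.3-fold lower number from compound 2 to compound 3 (0.64 log units; beyond the scatter). Compound 4 `FC(F)(F)c1ccc(Nc2nc(CN3CCN(C4CCCC4)CC3)nc3cc(-c4ncccc4C(F)(F)F)ccc23)cc1` is not yet measured; its difference from compound 3 is 4-cyclopentylpiperazin-1-yl in place of cyclohexylamino on a saturated chain carbon bound to an aromatic carbon. Within the data shown here, no measured step exchanges the amine nitrogen bearing a hydrogen for a ring nitrogen of a piperazine. The nearest comparisons are a 4.3-fold lower number from compound 2 to compound 3 (0.64 log units; beyond the scatter), where cyclohexyl in place of methyl gave a modest lower number, and a 29-fold higher number from compound 1 to compound 2 (1.46 log units; beyond the scatter), where methylamino in place of ethoxy gave a large higher number. These bear only loosely on the present change, so in this assay a modest step or none beyond the scatter is expected, direction uncertain. Compound 4 is estimated at 10 nM, range 2 nM to 60 nM, an expected step of a 1.7-fold higher number from compound 3 to compound 4 (0.22 log units; within the scatter).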

Compound 4, half-maximal inhibitory concentration: 8 nM
Compound 4: middle estimate off by 1.3-fold (0.10 log units), on the high side; measured number inside the range.
By their numbers in this assay, from the lowest: compound 1; then compounds 3 and 4 (each within the scatter of the next); then compound 2.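

In this assay, the step of a 1.3-fold higher number from compound 3 to compound 4 (0.12 log units; within the scatter) stays within the scatter, so at this position the hydrogen-bond donor counted for cyclohexylamino can be exchanged for 4-cyclopentylpiperazin-1-yl, which has none, without a step beyond the scatter, although ring content and size change in the same exchange. The larger ring-bearing amine group also keeps the gain over methylamino, a 3.3-fold lower number from compound 2 to compound 4 (0.51 log units; beyond the scatter), while ethoxy remains ahead, an 8.9-fold higher number from compound 1 to compound 4 (0.95 log units; beyond the scatter). No measurement at hand accounts for these steps.

Still open, from the compounds shown here alone, is how much of the value of compound 4 rests on the cyclopentyl group, which a piperazine carrying methyl or acetyl in its place would test. A morpholine would test the need for the outer ring nitrogen, and a propoxy group would show whether a longer ether holds the level of ethoxy.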